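Methoxy to Ethoxy: an Expected Cytotoxicity Read-out

A few compounds are considered here, and "the series" means these few. Any claim that something is new, unique, unknown or untested is made for them only; others in the source may bear on it.

Compound 1 `C=C1CC[C@H]2C(C)(C)CCC[C@]2(C)[C@H]1C/C=C1\CC(O)OC1=O` and compound 2 `C=C1CC[C@H]2C(C)(C)CCC[C@]2(C)[C@H]1C/C=C1\CC(OC)OC1=O` share one core and differ only at an oxygen on a saturated carbon, where compound 2 carries a methyl in place of hydrogen. In an ADME assay on RAW264.7 cells (Mus musculus) for cytotoxicity, read by luminescence and CellTiter-Glo, with a stated time of 18 h, tested at 5 uM (on this read-out higher numbers stand for a weaker effect at the one concentration tested and lower numbers for a stronger effect), compound 1 gives 86.3%, while compound 2 gives 101%. Within the data shown here, the step of a number 14.7 percentage points higher from compound 1 to compound 2 (beyond the scatter) lies beyond the scatter, so compound 2 stands highest of the two numbers, with compound 1 as its only neighbour. Compound 3 `C=C1CC[C@H]2C(C)(C)CCC[C@]2(C)[C@H]1C/C=C1\CC(OCC)OC1=O` extends that same chain by one more carbon: methyl in place of hydrogen on a saturated chain carbon bound to an oxygen on a saturated carbon. Among the measured compounds shown here, only the step from compound 1 to compound 2 bears on this change, and it was modest. Since compound 2 already reads near the level at which no loss of signal is seen, the expected step of a number 2 percentage points lower from compound 2 to compound 3 (within the scatter) is small and within the scatter. Compound 3 is estimated at 99% in this assay, with a range from 85% to 112%.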

Compound 3, a percentage reported as activity, at one concentration (the size of the read-out at that concentration, not a potency): 94.9%
Estimate against measurement, compound 3: 4.1 percentage points above, and the stated range covers the measured number.
By their numbers in this assay, from the lowest: compounds 1, 3 and 2 (each within the scatter of the next, the first and the last beyond it).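

Going from methoxy to ethoxy gives a number 6.1 percentage points lower from compound 2 to compound 3 (within the scatter) in this assay, so adding this methyl on a saturated chain carbon bound to an oxygen on a saturated carbon has no effect that can be told from ordinary scatter. Ethyl in place of hydrogen on the oxygen gives a number 8.6 percentage points higher from compound 1 to compound 3 (within the scatter), so, unlike the methyl step from compound 1 to compound 2, it cannot be separated from the free hydroxyl of compound 1. Nothing available explains why the two ethers read as they do.

With only hydrogen, methyl and ethyl on this oxygen, the compounds shown establish no trend with chain length. Going by these compounds, whether a longer chain such as butyl on the oxygen, or an amine in place of the methoxy or ethoxy group, would give a clearly different reading remains open.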